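The compounds below may be only part of what the source reports. "The series", "measured", "known", "first", "only" and "open" are said of these compounds alone.

Compounds measured in an assay on HEK293 cells for displacement of a labelled ligand from Sigma non-opioid intracellular receptor 1 (Homo sapiens), read by scintillation counting, with a stated time of 120 min; a lower number here means a stronger inhibitor, a higher number a weaker inhibitor:
- compound 1 `c1cn(-c2ncnc3c2cnn3CCN2CCCCC2)cn1` — 13800 nM
- compound 2 `Cc1ccncc1-c1ncnc2c1cnn2CCN1CCCCC1` — 707 nM

On these two numbers compound 2 stands lowest; the only other point, compound 1, lies a 20-fold lower number from compound 1 to compound 2 (1.29 log units; beyond the scatter) away, a large step that pairs 1H-imidazol-1-yl with the weaker number and 4-methylpyridin-3-yl with the stronger one.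

Compound 3 `Cn1cnc(-c2ncnc3c2cnn3CCN2CCCCC2)c1` changes compound 2 at the same position: 1-methyl-1H-imidazol-4-yl in place of 4-methylpyridin-3-yl on an aromatic carbon. Going by the values given here, the one measured step that bears on this is the one from compound 1 to compound 2, a 20-fold lower number from compound 1 to compound 2 (1.29 log units; beyond the scatter). Compound 3 returns to a five-membered aromatic ring with 2 hetero atoms, as in compound 1, though 1-methyl-1H-imidazol-4-yl is not the same group as 1H-imidazol-1-yl, so how much of that step is undone is uncertain. A rise in the number beyond the scatter is expected, most of the way back toward compound 1, i.e. a 5.7-fold higher number from compound 2 to compound 3 (0.75 log units; beyond the scatter). The estimate for compound 3 in this assay is 4000 nM, with a range from 1000 nM to 15000 nM.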

Compound 3, inhibition constant: 11800 nM
Compound 3: the middle estimate sits 3.0-fold (0.47 log units) below what was measured, and the stated range covers the measured number.
By their numbers in this assay, from the lowest: compound 2; then compounds 3 and 1 (each within the scatter of the next).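

The return to a five-membered aromatic ring with 2 hetero atoms costs the whole of the earlier gain in this assay (a 17-fold higher number from compound 2 to compound 3 (1.22 log units; beyond the scatter)), so compound 2 remains the strongest of the three. Moving from 1H-imidazol-1-yl to 1-methyl-1H-imidazol-4-yl changes the attachment and adds a methyl, yet the result stays within the scatter (a 1.2-fold lower number from compound 1 to compound 3 (0.07 log units; within the scatter)), so at this position these two imidazole groups cannot be told apart. No supporting data bear on why the two groups match or why 4-methylpyridin-3-yl differs.

From the compounds shown here alone, only compound 2 carries a six-membered ring here, so it remains open whether that ring, its nitrogen or its methyl goes with the lower number. A plain phenyl, an unsubstituted pyridin-3-yl or a 2-methylphenyl at this position would separate these, and a longer chain in place of the ethyl link to the piperidine is also untested in this set.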